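This account rests on a few compounds, and the source may have more. Where it says the series, first, only, none or still open, it means among the compounds named here.

Compound 1 `CCCCCCCSc1cc(-c2ccccc2)c(-c2ccccc2)nn1`: in an assay on microsomes from liver for inhibition of sterol O-acyltransferase 1 (Rattus norvegicus) (a higher number here means a weaker inhibitor, a lower number a stronger inhibitor), compound 1 gives 76000 nM.
Compound 2 `CCCCCCCCCSc1cc(-c2ccccc2)c(-c2ccccc2)nn1`: in this assay compound 2 gives 116000 nM.
Compound 3 `O=C(O)CCCCCSc1cc(-c2ccccc2)c(-c2ccccc2)nn1`: in this assay compound 3 gives > 300000 nM, which is a limit of the assay and not a number.

Within the data shown here, compound 3 is the one compound of the three for which only a limit is known; it sits at the limit of > 300000 nM in this assay, at which 1 of the 3 values shown sits, so its distance from compounds 1 and 2 is known only as a floor. The step of an at least 3.9-fold higher number from compound 1 to compound 3 (0.59 log units; beyond the scatter) and the step of an at least 2.5-fold higher number from compound 2 to compound 3 (0.41 log units; beyond the scatter) both run toward weaker inhibition and both lie beyond the scatter. The step of a 1.5-fold higher number from compound 1 to compound 2 (0.18 log units; within the scatter), a lengthening of the chain with no acid present, stays within the scatter.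

Compound 4 `O=C(O)CCCCCCSc1cc(-c2ccccc2)c(-c2ccccc2)nn1` differs from compound 3 by carboxymethyl in place of carboxy on a saturated chain carbon, five bonds along the chain from a sulfur. Among the measured compounds shown here, no measured pair shows this exact change, an acid kept and the chain lengthened. The nearest comparison, compound 1 to compound 2, lengthened the chain without the acid and lay within the scatter; the two steps into compound 3 both end at a limit. Compound 4 is therefore expected to remain at or beyond that limit, with an expected step that the limit leaves unreadable from compound 3 to compound 4, not beyond the scatter. The estimate for compound 4 in this assay is 450000 nM, in a range from 150000 nM to 1500000 nM.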

Compound 4, half-maximal inhibitory concentration: > 300000 nM
Compound 4: a limit, no number; the forecaster's own chance of this, stated with the estimate: 70%; the middle value does not contradict the limit.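

Compound 4 extends the acid series by carboxymethyl in place of carboxy, and in this assay compound 4 gives > 300000 nM, which is a limit of the assay and not a number. Against the chains without an acid, the steps read an at least 3.9-fold higher number from compound 1 to compound 4 (0.59 log units; beyond the scatter) and an at least 2.5-fold higher number from compound 2 to compound 4 (0.41 log units; beyond the scatter), so the move toward weaker inhibition seen with compound 3 now holds at a second chain length, and neither acid goes against it. The step between the two acids cannot be read: the limit of > 300000 nM in this assay, at which 2 of the 4 values shown sit.

Whether the added chain carbon changes inhibition among the acids at all therefore stays hidden, and a number for either acid would need a read-out that reaches past this limit. Going by these compounds, what a chain ending in an amine, a primary amide or a methyl ester would give on the shared core, and whether a longer carboxylic acid chain would return within the range of the assay, remains open.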